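The compounds below may be only part of what the source reports. "The series", "measured", "known", "first", "only" and "open" are said of these compounds alone.

Measured so far:
Compound 1 `O=S(=O)(Nc1ccccc1)c1ccc(F)c2ncc(I)cc12` gives 23900 nM in an assay for inhibition of methylcytosine dioxygenase TET2 (Homo sapiens), read by mass spectrometry, with stated times of 30 min and 1 h; on this read-out higher numbers stand for weaker inhibition and lower numbers for stronger inhibition.
Compound 2 `O=S(=O)(NC1CCCCC1)c1ccc(F)c2ncc(I)cc12` gives only a limit in this assay, > 200000 nM.
Compound 3 `O=S(=O)(NCc1ccccc1)c1ccc(F)c2ncc(I)cc12` gives only a limit in this assay, > 200000 nM.

Compound 3 stands at the weak end of the numbers shown, at a limit rather than a number. The same holds for one other value in this assay (the limit of > 200000 nM in this assay, at which 2 of the 3 values shown sit). Going by the values given here, the steps from the one compound with a number are an at least 8.3-fold higher number from compound 1 to compound 2 (0.92 log units; beyond the scatter) and an at least 8.3-fold higher number from compound 1 to compound 3 (0.92 log units; beyond the scatter). Between the two limits, a step that the two limits leave unreadable from compound 2 to compound 3.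

Compound 4 `O=S(=O)(Nc1cccc(O)c1)c1ccc(F)c2ncc(I)cc12` differs from compound 3 by 3-hydroxyphenyl in place of benzyl on a sulfonamide nitrogen. The measured step that bears on it is the reverse of the change from compound 1 to compound 3: there a phenyl on the sulfonamide nitrogen was replaced by benzyl, and the number rose at least modestly to the limit. Putting an aryl group, here 3-hydroxyphenyl, directly back on the sulfonamide nitrogen is therefore expected to return the number toward that of compound 1, a step in this assay of an at least 10-fold lower number from compound 3 to compound 4 (1.00 log units; beyond the scatter). Among the compounds with values here, the added hydroxyl has no measured counterpart among the three compounds, so nothing shows whether it moves the number further either way. Compound 4 is estimated at 20000 nM, within 5000 nM to 100000 nM.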

Compound 4, half-maximal inhibitory concentration: > 200000 nM
Compound 4: only a limit was reported (the forecaster's own chance of this, stated with the estimate: 20%); middle value at least 10-fold (1.00 log units) away from the limit.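

Hydroxy in place of hydrogen on an aromatic carbon of the phenyl on the sulfonamide nitrogen gives, in this assay, an at least 8.3-fold higher number from compound 1 to compound 4 (0.92 log units; beyond the scatter), a step beyond the scatter. An aromatic ring set directly on the sulfonamide nitrogen is therefore not enough on its own to keep a readable number, which compound 1 alone could not show. The steps among compound 2, compound 3 and compound 4 cannot be read, and compound 1 remains the only compound in the series with a number: the limit of > 200000 nM in this assay, at which 3 of the 4 values shown sit.

On these data alone, how far compound 2, compound 3 and compound 4 lie past that limit stays unknown, so the three substituents on the sulfonamide nitrogen cannot be ranked against one another. As far as these compounds go, it also remains open whether the change in compound 4 belongs to the hydroxyl itself or to where it sits on the ring, a question that a methoxy group, an amine or a carboxylic acid on the same phenyl, or the hydroxyl at another ring carbon, would bear on.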